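The source may report more compounds than this note shows. Statements on the series, on what has been measured and on what is new or still open speak of the compounds shown alone.

Working notes on the series in a functional assay on NCI-H460 cells (Homo sapiens) for cytotoxicity, read by MTT assay, with a stated time of 3 days; a lower number here means a stronger inhibitor, a higher number a weaker inhibitor. Compound 1 `N#Cc1c(Cl)nc(SCc2nc3ccccc3[nH]2)nc1-c1ccccc1` gives 3.28 nM, compound 2 `N#Cc1c(Nc2ccccc2)nc(SCc2nc3ccccc3[nH]2)nc1-c1ccccc1` gives 4.54 nM, and compound 3 `CCNc1nc(SCc2nc3ccccc3[nH]2)nc(-c2ccccc2)c1C#N` gives 2.87 nM, which places compound 3 level with the other two within the scatter. Compound 4 `N#Cc1c(NNC(N)=S)nc(SCc2nc3ccccc3[nH]2)nc1-c1ccccc1` differs from compound 3 as follows: a group of 4 heavy atoms (1 carbon, 2 nitrogen, 1 sulfur; no ring) in place of a group of 2 heavy atoms (2 carbon; no ring), on a nitrogen on an aromatic ring, on a nitrogen on an aromatic ring. Among the compounds with values here, three measured steps bear on this: a 1.4-fold higher number from compound 1 to compound 2 (0.14 log units; within the scatter), a 1.1-fold lower number from compound 1 to compound 3 (0.06 log units; within the scatter) and a 1.6-fold lower number from compound 2 to compound 3 (0.20 log units; within the scatter). All are small, and the last is the exchange on that nitrogen. Within the data shown here, no measured compound carries the entering group, so the range stays wide. No shift beyond the scatter is expected, in either direction, and the expected step is a 1.2-fold higher number from compound 3 to compound 4 (0.09 log units; within the scatter). For compound 4 the estimated value is 3.5 nM, with an expected range of 1.5 nM to 8 nM.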

Compound 4, half-maximal inhibitory concentration: 3.37 nM
For compound 4 the middle estimate is 1.0-fold (0.02 log units) above the measured one; the range from low to high includes it.
By their numbers in this assay, from the lowest: compounds 3, 1, 4 and 2 (each within the scatter of the next).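

The thiourea-bearing group of compound 4, the first here with hydrogen-bond donors and sulfur in this substituent, stays level with ethyl in this assay (a 1.2-fold higher number from compound 3 to compound 4 (0.07 log units; within the scatter)). It also stays level with anilino (a 1.3-fold lower number from compound 2 to compound 4 (0.13 log units; within the scatter)) and with chloro on the aromatic carbon (a 1.0-fold higher number from compound 1 to compound 4 (0.01 log units; within the scatter)), so all four compounds sit within the scatter despite very different substituents. No evidence on a cause bears on this result. From the compounds shown here alone, whether any substituent here can shift the number beyond the scatter remains open, for example a carboxylic acid or a longer chain on that nitrogen.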